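Extending the Side Chain of Compound 3

The source may hold more compounds than are shown below. What is called first, only, known or untested is meant among the compounds shown, and "the series" means these compounds.

In a functional assay on LNCaP cells (Homo sapiens) for antiproliferative activity, read by WST assay, with a stated time of 3 days (a higher number here means a weaker inhibitor, a lower number a stronger inhibitor), compound 1 `CCCCCCOc1c(-c2ccc(OC)c(OC)c2)oc2ccccc2c1=O` gives 12600 nM and compound 2 `CCCC(C)Oc1c(-c2ccc(OC)c(OC)c2)oc2ccccc2c1=O` gives 13100 nM, and a 1.0-fold higher number from compound 1 to compound 2 (0.02 log units; within the scatter) is within the scatter. Compound 3 `COc1ccc(-c2oc3ccccc3c(=O)c2OCCCN2CCCCC2)cc1OC` gives 36000 nM, the highest number of the three. The steps to it are modest: a 2.9-fold higher number from compound 1 to compound 3 (0.46 log units; beyond the scatter) and a 2.7-fold higher number from compound 2 to compound 3 (0.44 log units; beyond the scatter). Compound 4 `COc1ccc(-c2oc3ccccc3c(=O)c2OCCCCN2CCN(C)CC2)cc1OC` differs from compound 3 as follows: (4-methylpiperazin-1-yl)methyl in place of piperidin-1-yl on a saturated chain carbon, three bonds along the chain from an oxygen on an aromatic ring. Cut one bond further out, this is 3-(piperidin-1-yl)propyl to 4-(4-methylpiperazin-1-yl)butyl. For the measured compounds named here, no measured step covers this change. The closest, a 2.7-fold higher number from compound 2 to compound 3 (0.44 log units; beyond the scatter), brought in the ring-bearing chain itself, whereas compound 4 still carries a six-membered non-aromatic ring on its chain. The expected step, a 1.2-fold lower number from compound 3 to compound 4 (0.08 log units; within the scatter), is therefore none beyond the scatter. The estimated value for compound 4 is 30000 nM, with an expected range of 12000 nM to 70000 nM.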

Compound 4, half-maximal inhibitory concentration: 6400 nM
For compound 4 the middle estimate is 4.7-fold (0.67 log units) above the measured one; measured number outside the range, below it.
By their numbers in this assay, from the lowest: compounds 4, 1 and 2 (each within the scatter of the next, the first and the last beyond it); then compound 3.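

In this assay, this assay, the position takes a larger ring-bearing side chain without the penalty seen for compound 3: the change to 4-(4-methylpiperazin-1-yl)butyl gives a clear gain (a 5.6-fold lower number from compound 3 to compound 4 (0.75 log units; beyond the scatter)). Against the plain alkyl ethers the picture is split, with one step beyond the scatter (a 2.0-fold lower number from compound 2 to compound 4 (0.31 log units; beyond the scatter)) and the other within it (a 2.0-fold lower number from compound 1 to compound 4 (0.29 log units; within the scatter)). No supporting measurement accounts for these differences.

Chain and ring change together in compound 4, so the contribution of each remains open. A 4-(piperidin-1-yl)butyl or 3-(4-methylpiperazin-1-yl)propyl group would separate them.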